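The source may hold more compounds than are shown below. What is called first, only, known or untested is meant among the compounds shown, and "the series" means these compounds.

Within the data shown here, in an ADME assay on the whole organism (Rattus norvegicus) for pharmacokinetics, at a dose of 1 mg/kg by the intravenous route (a higher number here means more compound in the circulation at the dose given, a lower number less compound in the circulation), compound 1 `N#Cc1cnc(N2CCC(C(=O)N3N=CC[C@H]3c3cc(F)cc(F)c3)CC2)cn1` gives 400 ng.h/mL and compound 2 `Cc1nnc(N2CCC(C(=O)N3N=CC[C@H]3c3cc(F)cc(F)c3)CC2)o1` gives 1300 ng.h/mL as the higher of the two numbers so far. Among the measured compounds shown here, only one measured step bears on what follows: a 3.3-fold higher number from compound 1 to compound 2 (0.51 log units; beyond the scatter) when 5-methyl-1,3,4-oxadiazol-2-yl takes the place of 5-cyanopyrazin-2-yl on the amine nitrogen in a ring.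

Compound 3 `N#Cc1cc(N2CCC(C(=O)N3N=CC[C@H]3c3cc(F)cc(F)c3)CC2)ncn1` has not yet been measured. Its change from compound 2 at that same amine nitrogen is this: a group of 8 heavy atoms (5 carbon, 3 nitrogen; one six-membered aromatic ring with 2 hetero atoms) in place of a group of 6 heavy atoms (3 carbon, 2 nitrogen, 1 oxygen; one five-membered aromatic ring with 3 hetero atoms), on an amine nitrogen in a ring with 1 triple bond outside aromatic rings in the group that enters. The entering group looks more like the 5-cyanopyrazin-2-yl of compound 1 than like the group it replaces, although the two are not the same. The step to compound 2 can therefore be read in reverse, which points to a lower number in this assay of a similar, modest size. A single step is thin support, so the range stays wide. The expected change is a 2.6-fold lower number from compound 2 to compound 3 (0.41 log units; beyond the scatter) by this estimate. Compound 3 is expected at about 500 ng.h/mL with an estimated range of 220 ng.h/mL to 1100 ng.h/mL for repeated measurements.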

Compound 3, area under the concentration-time curve: 410 ng.h/mL
Beside the measured number, compound 3's estimate is 1.2-fold (0.09 log units) above it; low and high end bracket the measured number.
By their numbers in this assay, from the lowest: compounds 1 and 3 (each within the scatter of the next); then compound 2.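

In this assay, a second six-membered group now sits well below the 5-methyl-1,3,4-oxadiazol-2-yl compound, with a 3.2-fold lower number from compound 2 to compound 3 (0.50 log units; beyond the scatter), so the gap first seen with compound 1 is not tied to the 5-cyanopyrazin-2-yl group alone. The two nitrile-bearing six-membered groups have the same counts of carbon and nitrogen atoms but are not the same group, and the result gives no sign that this difference matters on the amine nitrogen in a ring, with a 1.0-fold higher number from compound 1 to compound 3 (0.01 log units; within the scatter). Among these three compounds, the five-membered group goes with the highest number, but nothing measured here tells why the number moves with this change.

The compounds shown change several features at once: ring size, the methyl group and the nitrile all differ together, so it remains open which of them goes with the higher number. A 1,3,4-oxadiazol-2-yl group without the methyl, or a pyrazin-2-yl group without the nitrile, would help to pull these features apart in this assay.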